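Benzhydryl-piperazine series: chain-linked bicyclic head groups

The source may report more compounds than this note shows. Statements on the series, on what has been measured and on what is new or still open speak of the compounds shown alone.

Compound 3 `O=c1[nH]c2ccccc2n1CCCCCN1CCN(C(c2ccccc2)c2ccccc2)CC1` gives 560 nM in an assay on RPMI-8226 cells for antagonist activity at P2X purinoceptor 7 (Homo sapiens), read by calcium flux (a higher number here means a weaker inhibitor, a lower number a stronger inhibitor), the lowest of the two numbers available. Compound 1 `O=C(C(c1ccccc1)c1ccccc1)N1CCN(CCCn2c(=O)[nH]c3ccccc32)CC1` gives 7800 nM in this assay, a higher number than compound 3 by a margin that is beyond the scatter. Compound 2 `O=c1[nH]c2ccccc2n1CCCN1CCN(S(=O)(=O)c2ccc(F)cc2)CC1` gives only a limit in this assay, > 10000 nM, which is not a number; this is the limit of > 10000 nM in this assay, at which 1 of the 3 values shown sits. Going by the values given here, no step between two measured compounds that differ in one place is available, so compound 3 stands on its own.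

Compound 4 `N#Cc1cn(CCCCN2CCN(C(c3ccccc3)c3ccccc3)CC2)c2ccccc12` is not yet measured. It differs from compound 3 by a group of 11 heavy atoms (9 carbon, 2 nitrogen; one five-membered aromatic ring with 1 hetero atom, one six-membered aromatic ring of carbon only) in place of a group of 11 heavy atoms (8 carbon, 2 nitrogen, 1 oxygen; one five-membered aromatic ring with 2 hetero atoms, one six-membered aromatic ring of carbon only), on a saturated chain carbon, four bonds along the chain from an amine nitrogen in a ring. Among the compounds with values here, the change keeps the benzhydryl-piperazine end and replaces the head group, and no measured pair shows what such a swap does. The expectation is a step from compound 3 to compound 4 of a 1.8-fold higher number from compound 3 to compound 4 (0.25 log units; within the scatter), that is a small loss, not clearly beyond the scatter. Compound 4 is therefore estimated at 1000 nM in this assay, within a range of 250 nM to 4000 nM.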

Compound 4, half-maximal inhibitory concentration: 1500 nM
For compound 4 the middle estimate is 1.5-fold (0.18 log units) below the measured one; the range from low to high includes it.
By their numbers in this assay, from the lowest: compound 3; then compound 4; then compound 1. At a limit, above all of these: compound 2.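

In this assay the position tolerates a head group with 0 hydrogen-bond donors and a triple bond outside the rings, at a modest cost: a 2.7-fold higher number from compound 3 to compound 4 (0.43 log units; beyond the scatter). The hydrogen-bond donor of the group that leaves is therefore not required for measurable inhibition in this benzhydryl-piperazine series, although the step also carries a shorter chain in compound 4, so head group and chain length are not separated. Nothing measured here gives a reason for the step.

Going by these compounds, whether the loss follows from the head group or from the chain remains open, and a matched pair with equal chains would settle it. Also open, on these data alone, is how an amine or a carboxylic acid in place of the nitrile, or a longer chain on this head group, would read in this assay.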